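Swapping Methylsulfanyl for Trifluoromethoxy in a Cytotoxicity Series

The source may report more compounds than this note shows. Statements on the series, on what has been measured and on what is new or still open speak of the compounds shown alone.

Measured compounds:
compound 1 `CSc1ccc(NC(=O)Nc2cc(C)nc3ccccc23)cc1` — > 25000 nM
compound 2 `Cc1cc(NC(=O)Nc2ccc3[nH]cnc3c2)c2ccccc2n1` — > 25000 nM

In an ADME assay on Raji cells (Homo sapiens) for cytotoxicity, with a stated time of 72 h (a lower number here means that less compound is needed, a higher number that more compound is needed for the effect), compound 1 gives > 25000 nM, which is a limit of the assay rather than a number. In this assay compound 2 likewise gives > 25000 nM, also a limit. Both measured values therefore sit at the limit of > 25000 nM in this assay, at which 2 of the 2 values shown sit, so compound 1 stands at the ceiling with no measurable potency.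

Compound 3 `Cc1cc(NC(=O)Nc2ccc(OC(F)(F)F)cc2)c2ccccc2n1` is not yet measured. It differs from compound 1 by trifluoromethoxy in place of methylsulfanyl on an aromatic carbon. With compound 1 at a limit, no step beyond the scatter is expected; the estimated step that the limit leaves unreadable from compound 1 to compound 3 is effectively none, and compound 3 is expected to give 30000 nM, within 10000 nM to 100000 nM.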

Compound 3, half-maximal effective concentration: 10000 nM
The estimate for compound 3 lay 3.0-fold (0.48 log units) above the measured number; the range from low to high includes it.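

In this assay, the aromatic carbon para to a large group turns out to be a place where a single change can shift the read-out: trifluoromethoxy in place of methylsulfanyl gives an at least 2.5-fold lower number from compound 1 to compound 3 (0.39 log units; beyond the scatter). Compound 1 gives > 25000 nM, which is a limit, so the step has a floor but no upper end. Compound 3 is the only compound shown with a number rather than a limit: the limit of > 25000 nM in this assay, at which 2 of the 3 values shown sit.

Going by these compounds, how large the step truly is remains open. So does whether an amine or a carboxylic acid on this carbon would move the number, and in which direction.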